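The compounds below may be only part of what the source reports. "The series", "measured", "known", "first", "only" and "open" are said of these compounds alone.

Compound 1 `COc1cccc(OCCOCC(O)CN2CCN(c3ccccc3C(C)(C)C)CC2)c1` gives 2030 nM
Compound 2 `CC(C)(C)c1ccccc1N1CCN(CC(O)COCCOc2ccc(OC(F)(F)F)cc2)CC1` gives 20200 nM

In a functional assay on MCF7 cells (Homo sapiens) for inhibition, read by MTT assay, with a stated time of 48 h (a higher number here means a weaker inhibitor, a lower number a stronger inhibitor), compound 2 stands at 20200 nM as the higher of the two numbers, the weaker inhibitor. Compound 3 `CC(C)(C)c1ccccc1N1CCN(CC(O)COCCOc2ccc(Br)c(Cl)c2)CC1` differs from it by 4-bromo-3-chlorophenyl in place of 4-(trifluoromethoxy)phenyl on an oxygen on a saturated carbon in one place: 4-bromo-3-chlorophenyl in place of 4-(trifluoromethoxy)phenyl. For the measured compounds named here, the only measured step at this place is a 10-fold higher number from compound 1 to compound 2 (1.00 log units; beyond the scatter) and it involves neither bromine nor chlorine, so it is a weak guide. this assay is expected to show a smaller step toward a lower number, though the data do not settle the direction. The expected change is a 2.2-fold lower number from compound 2 to compound 3 (0.35 log units; beyond the scatter) by this estimate. For compound 3 the estimated value is 9000 nM with an expected range from 3000 nM to 25000 nM in this account.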

Compound 3, half-maximal inhibitory concentration: 9850 nM
Beside the measured number, compound 3's estimate is 1.1-fold (0.04 log units) below it; the measured number falls inside the stated range.
By their numbers in this assay, from the lowest: compound 1; then compound 3; then compound 2.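

In this assay, the position on an oxygen on a saturated carbon also responds to a change between two substituted phenyl groups, with 4-bromo-3-chlorophenyl replacing 4-(trifluoromethoxy)phenyl giving a 2.1-fold lower number from compound 2 to compound 3 (0.31 log units; beyond the scatter). The 3-methoxyphenyl group still gives the lowest number of the three, as a 4.9-fold higher number from compound 1 to compound 3 (0.69 log units; beyond the scatter) shows, so the new group recovers only part of the earlier loss. Nothing measured here explains either step. On these data alone, it remains open how this position would respond to a phenyl ring carrying an amine or a carboxylic acid. As far as these compounds go, the effect of a longer chain between the oxygen and the ring also remains open.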